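An Acetoxy Group in Place of a Sulfonyl Amino Group

This account rests on a few compounds, and the source may have more. Where it says the series, first, only, none or still open, it means among the compounds named here.

Compound 1 `COc1ccc(-c2c(C)nc3c(N4CC[C@@H](NS(=O)(=O)c5ccccc5)C4)cc(C)nn23)cc1OC` and compound 2 `COc1ccc(-c2c(C)nc3c(N4CC[C@@H](NS(=O)(=O)c5cccs5)C4)cc(C)nn23)cc1OC` share one core and differ only in the group on the sulfonyl sulfur, thiophen-2-yl in place of phenyl. In an ADME assay on microsomes from liver (Homo sapiens) for metabolic stability, read by LC-MS, with NADPH named in the record, with a stated time of 60 min, tested at 1 uM, in the absence of a further agent (a lower number here means that less of the compound is left, a higher number that more of the compound is left), compound 1 gives > 95%, which is a limit of the assay rather than a number. In this assay compound 2 gives > 95%, again a limit. The step that the two limits leave unreadable from compound 1 to compound 2 can therefore not be read in size; all that the two values show is the limit of > 95% in this assay, at which 2 of the 2 values shown sit, so compound 2 stands at the top of what this assay reports.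

Compound 3 `COc1ccc(-c2c(C)nc3c(N4CC[C@@H](OC(C)=O)C4)cc(C)nn23)cc1OC` has not yet been measured in this assay. It differs from compound 2 by acetoxy in place of ((thiophen-2-yl)sulfonyl)amino on a saturated ring carbon. Among the measured compounds shown here, no measured step bears on this change, since the only step recorded concerns the group on the sulfonyl sulfur and is itself unreadable. The expectation can rest only on where compound 2 stands. For compound 3 the estimate in this assay is 75%, with a range from 40% to 95%. The expected step is a number at least 20 percentage points lower from compound 2 to compound 3 (beyond the scatter), downward and beyond the scatter, though with wide uncertainty.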

Compound 3, percent of the compound remaining: > 95%
Compound 3: a limit, no number; the forecaster's own chance of this, stated with the estimate: 25%; at least 20 percentage points between middle value and limit.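

In this assay compound 3 gives > 95%, a limit of the assay rather than a number. The steps linking compound 3 to compound 1 and compound 2 therefore cannot be read in size: the limit of > 95% in this assay, at which 3 of the 3 values shown sit.

The compounds shown leave open how far compound 1, compound 2 and compound 3 differ in stability, and which change to the group on the saturated ring carbon, if any, would leave less compound remaining.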